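Swapping Methoxy for Chloro on a Shared Core

The compounds below may be only part of what the source reports. "The series", "measured", "known", "first", "only" and "open" are said of these compounds alone.

Compound 1, `Fc1ccc(-c2nc3cccnc3o2)cc1`: 27%
Compound 2, `c1ccc(-c2nc3cccnc3o2)cc1`: 55%
Compound 3, `COc1ccc(-c2nc3cccnc3o2)cc1`: 29%

These three compounds share one core and differ only in the group on the outer benzene ring; all were tested in a functional assay on the whole organism for inhibition, with Rattus norvegicus as the target, at a dose of 30 mg/kg; a higher number here means more inhibition at the dose given (going by the name of the read-out), a lower number less inhibition. Among the three numbers compound 3 stands second highest. Its nearest neighbour is compound 1, whose value lies within the scatter of compound 3, so the two cannot be told apart; its furthest is compound 2, which lies beyond the scatter above it.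

The next compound, compound 4, `Clc1ccc(-c2nc3cccnc3o2)cc1`, differs from compound 3 in one place: chloro in place of methoxy on an aromatic carbon.

Among the measured compounds shown here, two measured steps bear on this. Removing the methoxy gave a number 26 percentage points lower from compound 2 to compound 3 (beyond the scatter) read backwards, a modest change beyond the scatter. Exchanging fluoro for methoxy gave a number 2 percentage points higher from compound 1 to compound 3 (within the scatter), within the scatter, so a fluoro and a methoxy at this place behaved alike, while the unsubstituted compound 2 stood apart by a number 28 percentage points higher from compound 1 to compound 2 (beyond the scatter). Chloro has not been measured here; by analogy with fluoro, the step of a number 1 percentage points higher from compound 3 to compound 4 (within the scatter) is expected to stay within the scatter. Compound 4 is therefore estimated at 30%, with a range from 15% to 50%.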

Compound 4, a percentage reported as inhibition, in the whole organism at one dose (the size of the read-out at that dose, not a potency): 14%
The estimate for compound 4 lay 16 percentage points above the measured number; the measured number lies below the stated range.
By their numbers in this assay, from the lowest: compound 4; then compounds 1 and 3 (each within the scatter of the next); then compound 2.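

In this assay the groups on this aromatic carbon no longer form a single set: fluoro and methoxy could not be told apart, but chloro separates from both, with a number 15 percentage points lower from compound 3 to compound 4 (beyond the scatter) and a number 13 percentage points lower from compound 1 to compound 4 (beyond the scatter) at the same place on the shared core. So far, a substituent here could have seemed to matter only by being present, yet compound 4 shows that the choice of group also counts, even though chloro is a single atom and methoxy has two heavy atoms. The step from the unsubstituted compound is also the largest in this small set, with a number 41 percentage points lower from compound 2 to compound 4 (beyond the scatter) in a single change, and all three substituted compounds now sit beneath compound 2 with no exception among those shown.

On these data alone, whether an amine, a carboxylic acid or a longer alkyl chain at this place would also fall beneath compound 2, or rise above it, remains open. Nothing available here accounts for the gap between chloro and the other two groups.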